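The source may hold more compounds than are shown below. What is called first, only, known or untested is meant among the compounds shown, and "the series" means these compounds.

Among the three compounds measured so far, compound 3 `COC(=O)/C=C/c1cccc(N(Cc2ccc(-c3c(OC)cccc3OC)cc2)C(=O)C2CCCCC2)c1` gives the lowest number in an assay on isolated protein with Bile acid receptor (Homo sapiens) as the target (on this read-out lower numbers stand for an effect already at smaller amounts and higher numbers for an effect only at larger amounts of compound), namely 77 nM. Compound 1 `COC(=O)/C=C/c1cccc(N(Cc2ccc(/C=C/c3ccccn3)cc2)C(=O)C2CCCCC2)c1` gives 309 nM in this assay, and compound 2 `COC(=O)/C=C/c1cccc(N(Cc2ccc(/C=C/c3scnc3C)cc2)C(=O)C2CCCCC2)c1` gives 227 nM. The move to compound 3 brought a 4.0-fold lower number from compound 1 to compound 3 (0.60 log units; beyond the scatter) and a 2.9-fold lower number from compound 2 to compound 3 (0.47 log units; beyond the scatter), so the 2,6-dimethoxyphenyl group stands out as the most favourable end group seen so far.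

Compound 4 `COC(=O)/C=C/c1cccc(N(Cc2ccc(Br)cc2)C(=O)C2CCCCC2)c1` changes that very group: bromo in place of 2,6-dimethoxyphenyl on an aromatic carbon. Going by the values given here, none of the measured steps covers such a change; all three exchanged one sizeable end group for another of comparable size, whereas here a whole ring is removed and a single atom is left. Among the compounds with values here, what the earlier steps do show is that the end group matters, with a 4.0-fold lower number from compound 1 to compound 3 (0.60 log units; beyond the scatter) being the largest difference recorded. An exchange of the best group for a far smaller one is therefore expected to cost potency, possibly by a larger margin than any step seen so far. Compound 4 is estimated at 700 nM in this assay, within a range of 200 nM to 3000 nM, which is expected to mean a 9.1-fold higher number from compound 3 to compound 4 (0.96 log units; beyond the scatter).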

Compound 4, half-maximal effective concentration: > 1000 nM
Compound 4 ended at the assay's limit; the forecaster's own chance of this, stated with the estimate: 10%; middle value at least 1.4-fold (0.15 log units) away from the limit.
By their numbers in this assay, from the lowest: compound 3; then compounds 2 and 1 (each within the scatter of the next). At a limit, above all of these: compound 4.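

At this position, on an aromatic carbon para to a large group, a lone bromo falls behind all three larger end groups, with an at least 12-fold higher number from compound 3 to compound 4 (1.11 log units; beyond the scatter), an at least 4.4-fold higher number from compound 2 to compound 4 (0.64 log units; beyond the scatter) and an at least 3.2-fold higher number from compound 1 to compound 4 (0.51 log units; beyond the scatter). The earlier compounds shown here only compared ring-bearing end groups with one another, whereas compound 4 shows that in this assay losing the ring altogether costs more than any exchange among those groups. The value of compound 4 is a limit of the assay and not a number: the limit of > 1000 nM in this assay, at which 1 of the 4 values shown sits.

As far as these compounds go, whether a plain phenyl ring without the two methoxy groups, or a small group such as an amine, would lie nearer compound 3 or compound 4 stays open. The compounds shown also cannot separate the presence of a ring from the sheer number of atoms, as bromo differs from 2,6-dimethoxyphenyl in both.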